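Chloro in place of hydrogen: the next step in the series

The compounds below may be only part of what the source reports. "The series", "measured", "known", "first", "only" and "open" are said of these compounds alone.

Measured so far in a functional assay on the whole organism with Mus musculus as the target, in the rotarod test; on this read-out higher numbers stand for an effect only at larger amounts of compound and lower numbers for an effect already at smaller amounts
- compound 1 `NCC(=O)NCc1nncn1-c1ccc(Cl)cc1C(=O)c1ccccc1` gives 11.8 mg/kg
- compound 2 `Cc1nnc(CNC(=O)CN)n1-c1ccc(Cl)cc1C(=O)c1ccccc1F` gives 1.84 mg/kg
- compound 3 `Cc1nnc(CNC(=O)CN)n1-c1ccc(Cl)cc1C(=O)c1ccccc1` gives 3.94 mg/kg

Among these three numbers, compound 3 stands second highest, with compound 1 higher and compound 2 lower. Compound 4 `Cc1nnc(CNC(=O)CN)n1-c1ccc(Cl)cc1C(=O)c1ccccc1Cl` carries chloro in place of hydrogen on an aromatic carbon, ortho to a large group (chloro in place of hydrogen on an aromatic carbon). The closest measured change is fluoro leaving that same aromatic carbon, which gave a 2.1-fold higher number from compound 2 to compound 3 (0.33 log units; beyond the scatter) and counts as modest. Read in reverse, it points to a lower number when a halogen enters. The other measured change, methyl in place of hydrogen on an aromatic carbon, gave a 3.0-fold lower number from compound 1 to compound 3 (0.48 log units; beyond the scatter) and was also modest. It lies elsewhere in the molecule and bears only on the typical size of a single replacement. Among the measured compounds shown here, no chloro analogue has been measured, so a modest move towards a lower number is expected. The expected step is a 2.3-fold lower number from compound 3 to compound 4 (0.37 log units; beyond the scatter) on this reasoning. In this assay compound 4 is estimated at 1.7 mg/kg with 0.75 mg/kg to 3.8 mg/kg as the expected range.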

Compound 4, dose for half-maximal effect: 2.09 mg/kg
For compound 4 the middle estimate is 1.2-fold (0.09 log units) below the measured one; the measured number falls inside the stated range.
By their numbers in this assay, from the lowest: compounds 2, 4 and 3 (each within the scatter of the next, the first and the last beyond it); then compound 1.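

In this assay, chloro on this aromatic carbon, ortho to a large group, gives a 1.9-fold lower number from compound 3 to compound 4 (0.28 log units; within the scatter), so chloro does not separate from hydrogen here, although fluoro on the same carbon did, with a 2.1-fold higher number from compound 2 to compound 3 (0.33 log units; beyond the scatter). Exchanging one halogen for the other gives a 1.1-fold higher number from compound 2 to compound 4 (0.06 log units; within the scatter), so chloro and fluoro at this place cannot be told apart, and of the two halogens only fluoro has a step from hydrogen that lies beyond the scatter. No measured property of these compounds is available to account for this result.

From the compounds shown here alone, whether bromo, methyl or methoxy on this carbon would separate from hydrogen remains open. Also open, going by these compounds, is whether chloro at this place would read the same on the core of compound 1, which has hydrogen where compound 3 has methyl.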